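The compounds below may be only part of what the source reports. "The series", "measured", "known", "first", "only" and "open" are said of these compounds alone.

Compound 1 `CCOC(=O)Nc1ccc([Se]C#N)cc1` gives 9800 nM in a functional assay on CCRF-CEM cells (Homo sapiens) for cytotoxicity, read by MTT assay, with a stated time of 72 h; a lower number here means a stronger inhibitor of growth, a higher number a weaker inhibitor of growth. Going by the values given here, compound 2 `N#C[Se]c1ccc(NC(=O)Oc2ccc(Cl)cc2)cc1` gives 18300 nM in this assay; the two values lie within the usual scatter of each other, so neither compound is set apart by the numbers so far. Compound 3 `CCCCCCOC(=O)Nc1ccc([Se]C#N)cc1` differs from compound 1 by butyl in place of hydrogen on a saturated chain carbon, two bonds along the chain from an oxygen next to a carbonyl group. Among the compounds with values here, no measured pair shows this kind of change, so the size of the step is open. For compound 3 the expectation is a step of a 1.4-fold lower number from compound 1 to compound 3 (0.15 log units; within the scatter) in this assay, close to none beyond the scatter. Compound 3 is estimated at 7000 nM, within 2500 nM to 20000 nM.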

Compound 3, concentration for 50% growth inhibition: 19700 nM
The estimate for compound 3 lay 2.8-fold (0.45 log units) below the measured number; the measured number falls inside the stated range.
By their numbers in this assay, from the lowest: compounds 1, 2 and 3 (each within the scatter of the next).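

Butyl in place of hydrogen on a saturated chain carbon, two bonds along the chain from an oxygen next to a carbonyl group, gives the first one-place step in the series: a 2.0-fold higher number from compound 1 to compound 3 (0.30 log units; within the scatter) in this assay. At this position, the change from ethyl to hexyl therefore leaves the number within the scatter in this single pair. Nothing available here bears on the reason for this result.

As far as these compounds go, a longer chain, an amine or a carboxylic acid at this position remains open. A single pair also leaves any trend with chain length undefined.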